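A few compounds are considered here, and "the series" means these few. Any claim that something is new, unique, unknown or untested is made for them only; others in the source may bear on it.

Working notes on the series.

The three measured compounds share one core, and in a functional assay on SMMC-7721 cells (Homo sapiens) for antiproliferative activity, read by MTT assay, with a stated time of 72 h (a higher number here means a weaker inhibitor, a lower number a stronger inhibitor), the spread among them is modest. Compound 1 `CCC(=O)N(C)c1ccc2[nH]c(-c3n[nH]c4ccccc34)cc2n1` gives 33500 nM in this assay. Compound 2 `CN(C(=O)CCc1ccccc1)c1ccc2[nH]c(-c3n[nH]c4ccccc34)cc2n1` gives 20900 nM in this assay, a step of a 1.6-fold lower number from compound 1 to compound 2 (0.20 log units; within the scatter). Compound 3 `CN(C(=O)c1ccc(F)cc1)c1ccc2[nH]c(-c3n[nH]c4ccccc34)cc2n1` gives 9150 nM in this assay and thus holds the lowest number of the three, with steps of a 3.7-fold lower number from compound 1 to compound 3 (0.56 log units; beyond the scatter) and a 2.3-fold lower number from compound 2 to compound 3 (0.36 log units; beyond the scatter) separating it from the other two.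

Compound 4 `CN(C(=O)c1ccc(Cl)cc1)c1ccc2[nH]c(-c3n[nH]c4ccccc34)cc2n1` differs from compound 3 only by chloro in place of fluoro on an aromatic carbon. For the measured compounds named here, no measured pair reports a change of this kind: the steps from compound 1 to compound 3 and from compound 2 to compound 3 concern what sits on the carbonyl carbon and both lie in the modest range, while the halogen swap itself has no precedent here. The step from compound 3 to compound 4 is therefore expected to be small, estimated at a 1.1-fold lower number from compound 3 to compound 4 (0.06 log units; within the scatter), with no clear direction. Compound 4 is expected to give about 8000 nM in this assay, within a range from 3500 nM to 18000 nM.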

Compound 4, half-maximal inhibitory concentration: 2420 nM
Beside the measured number, compound 4's estimate is 3.3-fold (0.52 log units) above it, outside the stated range (below it).
By their numbers in this assay, from the lowest: compound 4; then compound 3; then compounds 2 and 1 (each within the scatter of the next).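

In this assay, for the compounds shown here, the halogen on the aromatic ring, untouched by the earlier steps, proves able to move the number: chloro in place of fluoro, para to a large group, gives a 3.8-fold lower number from compound 3 to compound 4 (0.58 log units; beyond the scatter) for an exchange of one heavy atom for one heavy atom. Going by these compounds alone, with 4-chlorophenyl on the carbonyl carbon, the replacement of phenethyl gives an 8.6-fold lower number from compound 2 to compound 4 (0.94 log units; beyond the scatter) and the replacement of ethyl gives a 14-fold lower number from compound 1 to compound 4 (1.14 log units; beyond the scatter) as the only large step. No measurement at hand accounts for the difference between chloro and fluoro at this position.

Going by these compounds, two halogens fix no pattern, so it stays open how bromo, methoxy or trifluoromethyl in the same place, or plain hydrogen there, would compare with them. On these data alone, the chloro gain is also read on this one amide only, and whether it carries over to a phenethyl chain with chloro on its ring remains open.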